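Moving the ring nitrogen: compound 3 to compound 4

The source may hold more compounds than are shown below. What is called first, only, known or untested is meant among the compounds shown, and "the series" means these compounds.

In a functional assay on the whole organism (strain Wistar) with Rattus norvegicus as the target, with a stated time of 15 days, at a dose of 100 mg/kg by the oral route (a lower number here means a weaker effect, a higher number a stronger effect of the compound at the dose given), compound 1 `O=C1NC(=O)/C(=C/c2ccc(OCCSc3nnc(-c4ccccc4)o3)cc2)S1` gives 33.1%. Compound 2 `O=C1NC(=O)/C(=C/c2ccc(OCCSc3nnc(Cc4ccccc4)o3)cc2)S1` gives 34.6% in this assay, and compound 3 `O=C1NC(=O)/C(=C/c2ccc(OCCSc3nnc(-c4cccnc4)o3)cc2)S1` gives 72.3%, the highest of the three numbers. The step of a number 1.5 percentage points higher from compound 1 to compound 2 (within the scatter) lies within the scatter, whereas a number 39.2 percentage points higher from compound 1 to compound 3 (beyond the scatter) and a number 37.7 percentage points higher from compound 2 to compound 3 (beyond the scatter) are both large and beyond it, so compound 3 stands clearly apart from compound 1 and compound 2 in this assay.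

Compound 4 `O=C1NC(=O)/C(=C/c2ccc(OCCSc3nnc(-c4ccncc4)o3)cc2)S1` differs from compound 3 by a single change: pyridin-4-yl in place of pyridin-3-yl on an aromatic carbon. The pyridin-3-yl leaves and a pyridin-4-yl enters on an aromatic carbon of the five-membered aromatic ring with two nitrogen and one oxygen; the two compounds have the same atoms, joined differently.

For the measured compounds named here, both large steps in this assay involve a pyridin-3-yl entering in place of phenyl or benzyl; no measured step moves the ring nitrogen within the six-membered aromatic ring. That nitrogen, the one hydrogen-bond acceptor of the group, is kept in compound 4, and no direct comparison exists, so the range must stay wide. Compound 4 is expected to shift by a number 7.3 percentage points lower from compound 3 to compound 4 (within the scatter), a step within the scatter. Compound 4 is therefore estimated at 65% in this assay, between 35% and 85%.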

Compound 4, a percentage reported as activity, at one dose (the size of the read-out at that dose, not a potency): 69.7%
Compound 4: the middle estimate sits 4.7 percentage points below what was measured, and the stated range covers the measured number.
By their numbers in this assay, from the lowest: compounds 1 and 2 (each within the scatter of the next); then compounds 4 and 3 (each within the scatter of the next).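

In this assay, pyridin-4-yl in place of pyridin-3-yl on an aromatic carbon of the five-membered aromatic ring with 2 nitrogen and 1 oxygen gives a number 2.6 percentage points lower from compound 3 to compound 4 (within the scatter), so the place of the ring nitrogen within the six-membered ring makes no difference that can be read here. The large gain seen earlier with pyridin-3-yl also appears with pyridin-4-yl, as a number 35.1 percentage points higher from compound 2 to compound 4 (beyond the scatter) and a number 36.6 percentage points higher from compound 1 to compound 4 (beyond the scatter) show, so among these four compounds it is not tied to one placement of that nitrogen: both pyridinyl compounds stand apart from the phenyl and benzyl compounds, and none of the four goes against this. No measurement at hand accounts for that separation.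

From the compounds shown here alone, whether a pyridin-2-yl group, a six-membered aromatic ring with a second ring nitrogen, or a phenyl carrying an amine or a carboxylic acid would reach the numbers of compound 3 and compound 4 remains open. As the read-out comes from a single dose, the compounds shown also leave open how the effects of compound 3 and compound 4 compare at other doses.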